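This account rests on a few compounds, and the source may have more. Where it says the series, first, only, none or still open, it means among the compounds named here.

Measured in a functional assay on MT4 cells (Homo sapiens) for cytotoxicity; on this read-out lower numbers stand for higher toxicity in this test and higher numbers for lower toxicity in this test:

- Compound 1 `CC(c1ccccc1)c1cc(O)nc(SC2CCCCC2)n1`: 149000 nM
- Compound 2 `CSc1nc(O)cc(C(C)c2c(F)cccc2F)n1`: 20800 nM
- Compound 3 `CSc1nc(O)c(C)c(C(C)c2c(F)cccc2F)n1`: > 200000 nM, a limit of the assay

Compound 3 stands at the limit of > 200000 nM in this assay, at which 1 of the 3 values shown sits, so it has no exact number. Compound 4 `CCCCSc1nc(O)c(C)c(C(C)c2c(F)cccc2F)n1` extends its methylsulfanyl to butylsulfanyl: propyl in place of hydrogen on a saturated chain carbon bound to a sulfur. For the measured compounds named here, the one measured step, an at least 9.6-fold higher number from compound 2 to compound 3 (0.98 log units; beyond the scatter), is a methyl change at a different place, so it gives no direct size for this change. Going by the values given here, compound 1, the only measured compound without methylsulfanyl, gives 149000 nM, which suggests no large fall. The expected change is an at least 2.0-fold lower number from compound 3 to compound 4 (0.30 log units; that floor lies within the scatter), a modest step towards lower numbers or none beyond the scatter. For compound 4 the estimate is 100000 nM, with an expected range of 30000 nM to 250000 nM.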

Compound 4, half-maximal cytotoxic concentration: 112000 nM
Estimate against measurement, compound 4: 1.1-fold (0.05 log units) below; the range from low to high includes it.
By their numbers in this assay, from the lowest: compound 2; then compounds 4 and 1 (each within the scatter of the next). At a limit, above all of these: compound 3.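

In this assay, replacing methylsulfanyl with butylsulfanyl gives an at least 1.7-fold lower number from compound 3 to compound 4 (0.25 log units; that floor lies within the scatter), so this change on the saturated chain carbon bound to a sulfur is not shown to shift the number beyond the scatter. Compound 3 gives > 200000 nM, which is a limit of the assay. The true size of the step therefore cannot be read, and only its floor is known: the limit of > 200000 nM in this assay, at which 1 of the 4 values shown sits.

From the compounds shown here alone, it remains open how a longer chain, or an amine at the end of the butyl chain, would read here. Also open, going by these compounds, is whether butylsulfanyl would shift the number where hydrogen, not methyl, sits on the aromatic carbon.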